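The source may hold more compounds than are shown below. What is called first, only, known or untested is meant among the compounds shown, and "the series" means these compounds.

Measured compounds:
compound 1 `O=C(O)/C=C/c1ccncc1-c1ccc2ccccc2c1` – in an assay on a protein complex for inhibition of CDK8/Cyclin C (Homo sapiens), with a stated time of 1 h, tested at 10 uM (a lower number here means less inhibition, a higher number more inhibition at the concentration tested (going by the name of the read-out)), compound 1 gives 102%
compound 2 `O=C(O)CCNC(=O)/C=C/c1ccncc1-c1ccc2ccccc2c1` – in this assay compound 2 gives 91%

Compound 2 stands lowest of the two numbers shown; its only neighbour is compound 1, and the step of a number 11 percentage points lower from compound 1 to compound 2 (beyond the scatter) is a modest one beyond the scatter, with (2-carboxyethyl)amino in place of hydroxy on the carbonyl carbon. Compound 3 `O=C(/C=C/c1ccncc1-c1ccc2ccccc2c1)NC1CC1` has not yet been measured in this assay. Its change from compound 2 is cyclopropyl in place of 2-carboxyethyl on an amide-type nitrogen. Among the measured compounds shown here, the one measured step that bears on this end of the molecule is a number 11 percentage points lower from compound 1 to compound 2 (beyond the scatter); it shows that what sits on the carbonyl carbon can be altered with only a modest loss, and that both members of the pair remain high. For the measured compounds named here, no measured step swaps the 2-carboxyethyl for any other group on the amide-type nitrogen, so the size of that exchange is unknown. A step of the same modest order, or none beyond the scatter, is therefore expected: the expected step is a number 6 percentage points lower from compound 2 to compound 3 (within the scatter). Compound 3 is estimated at 85%, within a range from 60% to 100%.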

Compound 3, a percentage reported as inhibition, at one concentration (the size of the read-out at that concentration, not a potency): 102%
Compound 3: the middle estimate sits 17 percentage points below what was measured; measured number above the stated range.
By their numbers in this assay, from the lowest: compound 2; then compounds 1 and 3 (each within the scatter of the next).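

Working from this assay, the step of a number 11 percentage points higher from compound 2 to compound 3 (beyond the scatter) shows that the substituent on the amide-type nitrogen can be exchanged with no loss, so the lower number of compound 2 belongs to the 2-carboxyethyl group and not to the amide link as such. The step of no change at the digits printed from compound 1 to compound 3 (within the scatter) adds that cyclopropylamino can stand in place of hydroxy on the carbonyl carbon, which means a free carboxylic acid directly on the carbonyl carbon is not needed to keep the read-out at the level of compound 1; a carboxyl group alone does not account for the lower number either, as compound 1 carries one and stands with compound 3. No supporting measurement bears on why the 2-carboxyethyl group goes with the lower number.

Still open, from the compounds shown here alone, is how far the amide-type nitrogen accepts other groups, such as cyclobutyl, cyclohexyl, a phenyl ring or a longer alkyl chain, and whether a dimethylamino group on the carbonyl carbon, with no amide hydrogen, behaves like cyclopropylamino. Going by these compounds, with compound 1 and compound 3 both so high at a single concentration, their relative potency also remains open.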